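Chloro for fluoro on the anilino ring of compound 1

The compounds below may be only part of what the source reports. "The series", "measured", "known", "first", "only" and "open" are said of these compounds alone.

Compound 1 `CN1CCN(CCCOc2cccc3nc(Nc4ccc(F)c(F)c4)ccc23)CC1` is the weakest-looking member of the three measured compounds in a functional assay on cells (Panel NCI-60 (60 carcinoma cell lines), Homo sapiens) for inhibition, read by sulforhodamine B assay, with a stated time of 48 h (a lower number here means a stronger inhibitor of growth, a higher number a weaker inhibitor of growth), where compound 1 gives 6760 nM. Compound 2 `CN1CCN(CCCOc2cccc3nc(Nc4cccc(Cl)c4)ccc23)CC1` gives 4170 nM and compound 3 `CN1CCN(CCCOc2cccc3nc(Nc4cc(Cl)cc(Cl)c4)ccc23)CC1` gives 3720 nM; both steps from compound 1, a 1.6-fold lower number from compound 1 to compound 2 (0.21 log units; within the scatter) and a 1.8-fold lower number from compound 1 to compound 3 (0.26 log units; within the scatter), lie within the scatter, as does a 1.1-fold lower number from compound 2 to compound 3 (0.05 log units; within the scatter), so the three numbers are not ordered with confidence.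

Compound 4 `CN1CCN(CCCOc2cccc3nc(Nc4ccc(Cl)c(F)c4)ccc23)CC1` differs from compound 1 by chloro in place of fluoro on an aromatic carbon, on the carbon ortho to a fluoro group and para to a large group. Among the compounds with values here, the step that bears on it most closely is the one from compound 1 to compound 2, which swaps a difluorophenyl for a chlorophenyl and stays within the scatter; the step from compound 1 to compound 3 reads the same way. A single chloro for fluoro exchange is therefore expected to move this assay little, at most toward a somewhat lower number, a 1.3-fold lower number from compound 1 to compound 4 (0.11 log units; within the scatter). Compound 4 is estimated at 5200 nM, with a range of 2600 nM to 10500 nM.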

Compound 4, concentration for total growth inhibition: 3890 nM
Beside the measured number, compound 4's estimate is 1.3-fold (0.13 log units) above it; the measured number falls inside the stated range.
By their numbers in this assay, from the lowest: compounds 3, 4, 2 and 1 (each within the scatter of the next).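

In this assay, chloro in place of fluoro on this carbon, ortho to a fluoro group and para to a large group, gives a 1.7-fold lower number from compound 1 to compound 4 (0.24 log units; within the scatter); this isolates a single-atom exchange on the 3,4-difluorophenyl ring, and that exchange stays within the scatter. The 4-chloro-3-fluorophenyl group gives a 1.0-fold higher number from compound 3 to compound 4 (0.02 log units; within the scatter) and a 1.1-fold lower number from compound 2 to compound 4 (0.03 log units; within the scatter), so no difference among these three chloro-bearing anilino groups can be read from the numbers. No measurement at hand explains these values or links them to a property of either halogen.

Going by these compounds, it remains open whether a non-halogen group on this carbon, such as methoxy, nitrile or a primary amine, would move the value beyond the scatter. On these data alone, it is also open whether the chloro for fluoro exchange would read the same with a longer chain on the ether oxygen.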